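Diacetylamino Replacing Amino: What the Numbers Suggest

The source may hold more compounds than are shown below. What is called first, only, known or untested is meant among the compounds shown, and "the series" means these compounds.

The series rests on three measured compounds and one awaiting measurement. Compound 1 `CC(=O)Nc1nccc(-c2ccncc2)n1` gives 52% in a functional assay on the whole organism for inhibition, with Rattus norvegicus as the target, with stated times of 1 h and 3.5 h, at a dose of 100 mg/kg by the oral route; a lower number here means less inhibition, a higher number more inhibition at the dose given (going by the name of the read-out). Compound 2 `Nc1ncc(-c2ccccc2)c(-c2ccncc2)n1` gives 48%, and compound 3 `CC(C)(C)c1nc(N)ncc1-c1ccccc1` gives 46%. Compound 3 is not separated from either of the other two beyond the usual scatter of this measurement, so the three read-outs are best taken as one level. Within the data shown here, the only single-place step among them, a number 2 percentage points lower from compound 2 to compound 3 (within the scatter), with tert-butyl in place of pyridin-4-yl on an aromatic carbon, confirms that picture.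

Compound 4 `CC(=O)N(C(C)=O)c1ncc(-c2ccccc2)c(C(C)(C)C)n1` is reached from compound 3 by diacetylamino in place of amino on an aromatic carbon. Among the measured compounds shown here, no measured step exchanges the amino group directly, but compound 1 already carries an acetylamino group and compound 3 an amino group, and their read-outs lie within the scatter of each other. Compound 4 is therefore expected to give 45%, within 25% to 65%, an expected step of a number 1 percentage points lower from compound 3 to compound 4 (within the scatter), not beyond the scatter.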

Compound 4, a percentage reported as inhibition, in the whole organism at one dose (the size of the read-out at that dose, not a potency): 22%
Beside the measured number, compound 4's estimate is 23 percentage points above it, and the stated range ends above it.
By their numbers in this assay, from the lowest: compound 4; then compounds 3, 2 and 1 (each within the scatter of the next).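

Diacetylamino in place of amino, on the aromatic carbon between two ring nitrogen atoms, gives a number 24 percentage points lower from compound 3 to compound 4 (beyond the scatter) in this assay, the only step shown that lies beyond the scatter. This place in the series therefore responds to what it carries, whereas the earlier step, a number 2 percentage points lower from compound 2 to compound 3 (within the scatter), changed a different place and did not separate its two compounds. The data shown offer no explanation for the step to compound 4.

Going by these compounds, it remains open whether a single acetylamino group on the core of compound 3 would stay level with the amino group or fall as far as the diacetylamino group does. The compounds shown also leave open how a methylamino group, a dimethylamino group or a longer acyl chain such as propanoylamino would read out at this place.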